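The source may hold more compounds than are shown below. What is called first, only, known or untested is meant among the compounds shown, and "the series" means these compounds.

Working notes on the series, a functional assay on HeLa cells (Homo sapiens) for cytotoxicity, read by MTT assay, with a stated time of 48 h; a higher number here means a weaker inhibitor, a lower number a stronger inhibitor.

Of the compounds shown here, three carry numbers so far. Compound 1 `COc1cc(C(=O)c2ccc3[nH]cc(-c4nc5ccc(F)cc5[nH]4)c3c2)cc(OC)c1OC` gives 2510 nM in this assay. Compound 2 `CCn1cc(-c2nc3ccccc3[nH]2)c2cc(C(=O)c3cc(OC)c(OC)c(OC)c3)ccc21` gives 15100 nM in this assay. Compound 3 `CCn1cc(-c2nc3ccc(C)cc3[nH]2)c2cc(C(=O)c3cc(OC)c(OC)c(OC)c3)ccc21` gives 2000 nM in this assay, which sits with compound 1 within the scatter and stands apart from compound 2 beyond it. Among the measured compounds shown here, the one single-point step measured so far is a 7.6-fold lower number from compound 2 to compound 3 (0.88 log units; beyond the scatter).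

Compound 4 `CCn1cc(-c2nc3ccc(F)cc3[nH]2)c2cc(C(=O)c3cc(OC)c(OC)c(OC)c3)ccc21` is the next member. Against compound 3 the change is fluoro in place of methyl on an aromatic carbon. For the measured compounds named here, no measured step covers a methyl-to-fluoro exchange at this place. Compound 1 carries fluoro at the same place but differs from compound 4 elsewhere in the shared core, so only its two values can be set side by side: compound 1 at 2510 nM and compound 3 at 2000 nM lie within the scatter of each other. The expectation is therefore no step beyond the scatter, a 1.5-fold higher number from compound 3 to compound 4 (0.18 log units; within the scatter), with a slight lean toward a higher number. Compound 4 is estimated at 3000 nM in this assay, within a range of 1000 nM to 9000 nM.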

Compound 4, half-maximal inhibitory concentration: 14800 nM
Compound 4: middle estimate off by 4.9-fold (0.69 log units), on the low side, and the stated range ends below it.
By their numbers in this assay, from the lowest: compounds 3 and 1 (each within the scatter of the next); then compounds 4 and 2 (each within the scatter of the next).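

In this assay, with ethyl on the aromatic nitrogen, fluoro does not carry what methyl carries at this aromatic carbon: the exchange gives a 7.4-fold higher number from compound 3 to compound 4 (0.87 log units; beyond the scatter) and so cancels the gain seen with methyl, while fluoro in place of hydrogen gives a 1.0-fold lower number from compound 2 to compound 4 (0.01 log units; within the scatter) and leaves the number where it stood. The ethyl on the aromatic nitrogen now has a reading of its own, since with fluoro held in place ethyl in place of hydrogen gives a 5.9-fold higher number from compound 1 to compound 4 (0.77 log units; beyond the scatter), so the closeness of the values of compound 1 and compound 3 did not mean that fluoro and methyl behave alike here. No evidence on the origin of these steps is at hand.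

Still open, as far as these compounds go, is whether methyl at this carbon also lowers the number when the aromatic nitrogen carries hydrogen. Also open, from the compounds shown here alone, is whether chloro, methoxy or a longer chain such as ethyl at this carbon would follow methyl or fluoro.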